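The source may hold more compounds than are shown below. What is called first, only, known or untested is meant among the compounds shown, and "the series" means these compounds.

Measured compounds:
- compound 1 `Cc1nnc(-c2sc(-c3cccc(F)c3)nc2O)o1` — 9100 nM in an assay on HEK293 cells for inhibition of transient receptor potential cation channel subfamily M member 8 (Homo sapiens), read by FLIPR, with stated times of 5 min and 3 min; a lower number here means a stronger inhibitor, a higher number a weaker inhibitor
- compound 2 `Cc1nc(-c2sc(-c3cccc(F)c3)nc2O)no1` — 1800 nM in this assay

The two measured compounds share a core and differ only in the five-membered heteroaryl group attached to it. For the measured compounds named here, the step of a 5.1-fold lower number from compound 1 to compound 2 (0.70 log units; beyond the scatter) is the only comparison in hand, and it shows that exchanging one such heteroaryl for another can move the number beyond the scatter. On these two numbers compound 2 stands lowest; its nearest neighbour is compound 1, and the gap between them is that same step.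

Compound 3 `Cn1nnc(-c2sc(-c3cccc(F)c3)nc2O)n1` carries the change (2-methyl-2H-tetrazol-5-yl in place of 5-methyl-1,2,4-oxadiazol-3-yl on an aromatic carbon). Going by the values given here, no measured step covers this particular exchange; the one that bears on it, a 5.1-fold lower number from compound 1 to compound 2 (0.70 log units; beyond the scatter), only shows the size a heteroaryl swap on this core can reach, not which direction a tetrazole would take. A step of at most similar size in this assay is therefore possible in either direction, and the central expectation is for no change beyond the scatter.

For compound 3 the estimated value in this assay is 2000 nM, with a range from 600 nM to 7000 nM; this is expected to mean a step of a 1.1-fold higher number from compound 2 to compound 3 (0.05 log units; within the scatter).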

Compound 3, half-maximal inhibitory concentration: 214 nM
Beside the measured number, compound 3's estimate is 9.3-fold (0.97 log units) above it; the measured number lies below the stated range.
By their numbers in this assay, from the lowest: compound 3; then compound 2; then compound 1.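

At the position on the aromatic carbon next to the ring sulfur, the result shows that the heteroaryl group can do more than the oxadiazole exchange suggested: in this assay, 2-methyl-2H-tetrazol-5-yl in place of 5-methyl-1,2,4-oxadiazol-3-yl gives an 8.4-fold lower number from compound 2 to compound 3 (0.92 log units; beyond the scatter) while the group stays at 6 heavy atoms. Against the other oxadiazole, the same tetrazole gives a 43-fold lower number from compound 1 to compound 3 (1.63 log units; beyond the scatter) and so makes compound 3 the strongest inhibitor of the three, with all three groups separated beyond the scatter. Nothing at hand accounts for this order among the three groups.

Open, going by these compounds, is whether a carboxylic acid or a primary amide on this same aromatic carbon would match the tetrazole, and whether an ethyl group in place of the methyl on the tetrazole would keep the number of compound 3. Also open, on these data alone, is whether the gain from the tetrazole would carry over if an amine replaced the hydroxy group on the shared core, since all three compounds keep the rest of that core unchanged.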